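Bulkier Ester Side Chain on an Already Weak Compound

A few compounds are considered here, and "the series" means these few. Any claim that something is new, unique, unknown or untested is made for them only; others in the source may bear on it.

Compound 1 `Cc1ccc(CNC(=O)c2[nH]cnc2C(=O)Nc2ccc(Cl)c(Cl)c2)cc1` gives 15200 nM in a functional assay on HL-60 cells (Homo sapiens), with a stated time of 4 days; a higher number here means a weaker inhibitor, a lower number a stronger inhibitor.
Compound 2 `COc1ccc(CNC(=O)c2[nH]cnc2C(=O)Nc2ccc(Cl)c(Cl)c2)cc1` gives 18300 nM in this assay.
Compound 3 `COC(=O)[C@@H](C)NC(=O)c1[nH]cnc1C(=O)Nc1ccc(Cl)c(Cl)c1` gives only a limit of this assay, > 62500 nM.

Compound 3 thus sits at the weak end of the three, at the limit of > 62500 nM in this assay, at which 1 of the 3 values shown sits, rather than at a measured number. The two steps that reach it, an at least 4.1-fold higher number from compound 1 to compound 3 (0.61 log units; beyond the scatter) and an at least 3.4-fold higher number from compound 2 to compound 3 (0.53 log units; beyond the scatter), both swap the whole benzyl-type group on the amide nitrogen for the ester-bearing chain, and both weaken inhibition beyond the scatter.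

Compound 4 `COC(=O)[C@H](NC(=O)c1[nH]cnc1C(=O)Nc1ccc(Cl)c(Cl)c1)C(C)C` keeps that chain and differs from compound 3 only by isopropyl in place of methyl on a saturated chain carbon bound to an amide-type nitrogen and a carbonyl carbon. Among the measured compounds shown here, no measured step alters the size of this chain group while leaving the rest in place, so the two steps above bear on it only loosely: they show how weak the ester-chain series already is. The expectation for compound 4 is therefore no shift beyond the scatter, a step that the limit leaves unreadable from compound 3 to compound 4, with the result most likely remaining a limit. The estimated value for compound 4 is 75000 nM, with a range from 30000 nM to 200000 nM.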

Compound 4, half-maximal inhibitory concentration: 4900 nM
The estimate for compound 4 lay 15-fold (1.18 log units) above the measured number; measured number below the stated range.
By their numbers in this assay, from the lowest: compound 4; then compounds 1 and 2 (each within the scatter of the next). At a limit, above all of these: compound 3.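

On the saturated chain carbon bound to an amide-type nitrogen and a carbonyl carbon, the size of the group clearly matters: in this assay, isopropyl in place of methyl gives an at least 12-fold lower number from compound 3 to compound 4 (1.10 log units; beyond the scatter). The ester-bearing chain is therefore not weak in itself, since the 1-(methoxycarbonyl)-2-methylpropyl group also outperforms both benzyl-type groups, with a 3.7-fold lower number from compound 2 to compound 4 (0.57 log units; beyond the scatter) and a 3.1-fold lower number from compound 1 to compound 4 (0.49 log units; beyond the scatter). The true size of the methyl-to-isopropyl step stays unknown, and compound 3 gives a limit rather than a number: the limit of > 62500 nM in this assay, at which 1 of the 4 values shown sits.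

What an ethyl or a tert-butyl group would do on this carbon remains open, so the compounds shown cannot tell whether the gain continues with size or stops. The effect of a free carboxylic acid in place of the methyl ester is open too.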